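Selenocyanate carbamates: chain extension on the ester

This account rests on a few compounds, and the source may have more. Where it says the series, first, only, none or still open, it means among the compounds named here.

Working notes on a small set of aryl carbamates carrying selenium. Compound 1 `CC(C)COC(=O)Nc1ccc([Se][Se]c2ccc(NC(=O)OCC(C)C)cc2)cc1` gives 77400 nM in a functional assay on HT-29 cells (Homo sapiens) for cytotoxicity, read by MTT assay, with a stated time of 72 h; a lower number here means that less compound is tolerated, a higher number that more compound is tolerated; compound 3 `CCOC(=O)Nc1ccc([Se][Se]c2ccc(NC(=O)OCC)cc2)cc1` gives 76100 nM, and compound 2 `CCCCOC(=O)Nc1ccc([Se]C#N)cc1` gives 63700 nM. All three numbers sit within the usual scatter of one another, so compound 2 stands alongside the other two with no gap beyond the scatter in this assay. Compound 4 `CCCCCCOC(=O)Nc1ccc([Se]C#N)cc1` differs from compound 2 by the change (ethyl in place of hydrogen on a saturated chain carbon, four bonds along the chain from an oxygen next to a carbonyl group), ethyl in place of hydrogen on a saturated chain carbon, four bonds along the chain from an oxygen next to a carbonyl group. Among the compounds with values here, no measured pair shows such a chain extension, and the diselenides with different ester chains agree within scatter, so no step beyond the scatter is expected in this assay. Compound 4 is estimated at 60000 nM, within 25000 nM to 150000 nM. The expected step from compound 2 to compound 4 is a 1.1-fold lower number from compound 2 to compound 4 (0.03 log units; within the scatter).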

Compound 4, concentration lethal to 50% of the cells: 69900 nM
The estimate for compound 4 lay 1.2-fold (0.07 log units) below the measured number, and the stated range covers the measured number.
By their numbers in this assay, from the lowest: compounds 2, 4, 3 and 1 (each within the scatter of the next).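

In this assay, within the data shown here, ethyl in place of hydrogen at this place on the ester chain gives a 1.1-fold higher number from compound 2 to compound 4 (0.04 log units; within the scatter), so this pair offers a direct reading of a chain extension on the selenocyanate carbamates, which the earlier compounds could not give. At this place, the change leaves the number within the scatter. No available measurement bears on the reason for this result.

From the compounds shown here alone, whether a longer chain, or an amine or a carboxylic acid in place of the ethyl, would give a step beyond the scatter remains open.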